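Sulfonyl substituent swap in the pyrrolopyridinone acetic acid series

The source may hold more compounds than are shown below. What is called first, only, known or untested is meant among the compounds shown, and "the series" means these compounds.

Measured so far:
compound 1 `Cc1c(Cc2cc(Br)ccc2S(=O)(=O)c2ccccc2)c2c(n1CC(=O)O)CCNC2=O` — 3.9 nM
compound 2 `CNC(=O)c1cccc(S(=O)(=O)c2ccccc2Cc2c3c(n(CC(=O)O)c2C)CCNC3=O)c1` — 240 nM
compound 3 `Cc1c(Cc2ccccc2S(=O)(=O)c2ccc(Cl)cc2)c2c(n1CC(=O)O)CCNC2=O` — 8.5 nM

All three numbers come from a functional assay on CHO.K1 cells for antagonist activity at prostaglandin D2 receptor 2 (Homo sapiens), read by GTPgammaS binding, with a stated time of 1 h; on this read-out higher numbers stand for weaker inhibition and lower numbers for stronger inhibition. Compound 3 stands second highest of the three; its nearest neighbour is compound 1, and the gap between compound 1 and compound 3 is beyond the scatter, while compound 2 sits far higher.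

Compound 4 `Cc1c(Cc2ccccc2S(=O)(=O)C2CCCCC2)c2c(n1CC(=O)O)CCNC2=O` is not yet measured. The change from compound 3 is cyclohexyl in place of 4-chlorophenyl on a sulfonyl sulfur. Within the data shown here, the only step that touches this position is a 28-fold lower number from compound 2 to compound 3 (1.45 log units; beyond the scatter), which shows that the group on the sulfonyl sulfur can move this assay a long way. Among the measured compounds shown here, no measured pair exchanges an aromatic ring for a non-aromatic one here, so the direction is open. A moderate step is expected for compound 4, leaning towards a higher number: a 2.4-fold higher number from compound 3 to compound 4 (0.37 log units; beyond the scatter). The estimate for compound 4 is 20 nM, with a range from 5 nM to 80 nM.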

Compound 4, half-maximal inhibitory concentration: 28 nM
Compound 4: middle estimate off by 1.4-fold (0.15 log units), on the low side; the range from low to high includes it.
By their numbers in this assay, from the lowest: compound 1; then compound 3; then compound 4; then compound 2.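

In this assay, the sulfonyl sulfur does not need an aromatic ring to keep a low number: cyclohexyl in place of 4-chlorophenyl gives only a 3.3-fold higher number from compound 3 to compound 4 (0.52 log units; beyond the scatter), a modest step beyond the scatter. Cyclohexyl also stands well clear of 3-(methylcarbamoyl)phenyl, with an 8.6-fold lower number from compound 2 to compound 4 (0.93 log units; beyond the scatter). No measurement here explains either step.

Open, as far as these compounds go, is whether the step from compound 3 to compound 4 follows the loss of the chlorine or of the aromatic ring; unsubstituted phenyl on the same core would separate the two. Also open, from the compounds shown here alone, is how a smaller group such as methyl, or a ring carrying an amine, would read.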